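Replacing 2-fluorophenyl with cyclohexyl

The source may report more compounds than this note shows. Statements on the series, on what has been measured and on what is new or still open speak of the compounds shown alone.

In a functional assay on MCF7 cells (Homo sapiens) for antiproliferative activity, read by MTT assay (on this read-out higher numbers stand for weaker inhibition and lower numbers for stronger inhibition), compound 1 `COc1cc2c(Oc3ccc(NC(=O)Nc4ccccc4)cc3)ccnc2cc1OCCCCCCC(=O)NO` gives 1040 nM and compound 2 `COc1cc2c(Oc3ccc(NC(=O)Nc4cccc(C)c4)cc3)ccnc2cc1OCCCCCCC(=O)NO` gives 1240 nM while compound 3 `COc1cc2c(Oc3ccc(NC(=O)Nc4ccccc4F)cc3)ccnc2cc1OCCCCCCC(=O)NO` gives 660 nM and so stands within the scatter of both. Compound 4 `COc1cc2c(Oc3ccc(NC(=O)NC4CCCCC4)cc3)ccnc2cc1OCCCCCCC(=O)NO` carries cyclohexyl in place of 2-fluorophenyl on an amide-type nitrogen. Among the compounds with values here, three measured steps bear on this only indirectly: (a 1.2-fold higher number from compound 1 to compound 2 (0.08 log units; within the scatter)), (a 1.6-fold lower number from compound 1 to compound 3 (0.20 log units; within the scatter)) and (a 1.9-fold lower number from compound 2 to compound 3 (0.27 log units; within the scatter)). All are small, and none replaces an aromatic ring with a non-aromatic one. On that thin basis the expected step is a 1.5-fold higher number from compound 3 to compound 4 (0.18 log units; within the scatter) with nothing beyond the scatter anticipated. In this assay compound 4 is estimated at 1000 nM with 350 nM to 2800 nM as the expected range.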

Compound 4, half-maximal inhibitory concentration: 600 nM
Compound 4: middle estimate off by 1.7-fold (0.22 log units), on the high side, within the range that was stated.
By their numbers in this assay, from the lowest: compounds 4, 3, 1 and 2 (each within the scatter of the next, the first and the last beyond it).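

In this assay, an aromatic ring on this amide-type nitrogen proves not to be needed: cyclohexyl, a non-aromatic ring, stays within the scatter of 2-fluorophenyl (a 1.1-fold lower number from compound 3 to compound 4 (0.04 log units; within the scatter)) and of phenyl (a 1.7-fold lower number from compound 1 to compound 4 (0.24 log units; within the scatter)). Only the comparison with 3-methylphenyl passes the scatter, and modestly (a 2.1-fold lower number from compound 2 to compound 4 (0.32 log units; beyond the scatter)). Nothing available explains why the non-aromatic ring is tolerated.

Still open, as far as these compounds go, is whether an open chain such as butyl, or a ring carrying an amine, would also be tolerated at this nitrogen.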